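A few compounds are considered here, and "the series" means these few. Any claim that something is new, unique, unknown or untested is made for them only; others in the source may bear on it.

Two measured compounds share one core and differ only in a single group on a six-membered aromatic ring of carbon only. Compound 1 `O/N=C(/Nc1cccc(F)c1)c1ccc2occc2c1` carries fluoro there, and in an assay on tissue (HeLa cells) for inhibition of Indoleamine 2,3-dioxygenase 1 (Homo sapiens), read by spectrophotometry (on this read-out higher numbers stand for weaker inhibition and lower numbers for stronger inhibition), compound 1 gives 20000 nM. Compound 2 `O/N=C(/Nc1cccc(C(F)(F)F)c1)c1ccc2occc2c1` carries trifluoromethyl in the same place, and in this assay compound 2 gives 1900 nM. Within the data shown here, that single exchange produced an 11-fold lower number from compound 1 to compound 2 (1.02 log units; beyond the scatter), so compound 2 holds the lower of the two measured numbers, with compound 1 its only neighbour. Compound 3 `O/N=C(/Nc1cccc(Cc2ccccc2)c1)c1ccc2occc2c1` differs from compound 2 at that same position, with benzyl in place of trifluoromethyl on an aromatic carbon. Among the measured compounds shown here, the only measured step that bears on this is the one from compound 1 to compound 2, where exchanging the group on that ring went with a much lower number. On that single precedent, a further but modest lowering is expected, with wide uncertainty. For compound 3 in this assay the estimate is 1000 nM, between 250 nM and 5000 nM, which means an expected step of a 1.9-fold lower number from compound 2 to compound 3 (0.28 log units; within the scatter).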

Compound 3, half-maximal inhibitory concentration: > 30000 nM
Compound 3: no number, only a limit (the forecaster's own chance of this, stated with the estimate: 5%); middle value at least 30-fold (1.47 log units) from the limit.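

Compound 3 gives a limit of the assay, not a number: the limit of > 30000 nM in this assay, at which 1 of the 3 values shown sits.

Even so, this position clearly does not reward every larger group: benzyl in place of trifluoromethyl brings an at least 15-fold higher number from compound 2 to compound 3 (1.19 log units; beyond the scatter), undoing the gain that trifluoromethyl had shown over fluoro. Benzyl in place of fluoro brings an at least 1.5-fold higher number from compound 1 to compound 3 (0.17 log units; that floor lies within the scatter), and with that floor inside the usual scatter, compound 3 cannot be clearly separated from compound 1.

Going by these compounds, the true number for compound 3 remains unknown, so both new steps have only a lower bound on their size. Also open, on these data alone, is how groups such as methyl, methoxy, an amine or a carboxylic acid would behave at this position, and whether any of them would match or improve on trifluoromethyl.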